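Adding a Methyl to Compound 2

The compounds below may be only part of what the source reports. "The series", "measured", "known", "first", "only" and "open" are said of these compounds alone.

Compound 1 `CCOC(=O)c1sc2cccc(C)c2c1Nc1cc(OC)c(OC)c(OC)c1`: 5670 nM
Compound 2 `COC(=O)c1sc2ccccc2c1Nc1cc(OC)c(OC)c(OC)c1`: 490 nM

In a functional assay on Jurkat cells (Homo sapiens) for cytotoxicity, read by MTT assay, with a stated time of 72 h (on this read-out lower numbers stand for stronger inhibition and higher numbers for weaker inhibition), compound 2 stands lowest of the two measured compounds at 490 nM, and the gap to compound 1 lies beyond the scatter. Compound 3 `COC(=O)c1sc2cccc(C)c2c1Nc1cc(OC)c(OC)c(OC)c1` follows from compound 2 with methyl in place of hydrogen on an aromatic carbon. Going by these compounds, compound 1 also carries this methyl and gives 5670 nM, but it differs from compound 2 in a second place as well, so the methyl's share remains unknown. A moderate rise is therefore expected, a 3.7-fold higher number from compound 2 to compound 3 (0.57 log units; beyond the scatter). The estimate for compound 3 is 1800 nM, with an expected range from 500 nM to 6000 nM.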

Compound 3, half-maximal inhibitory concentration: 6710 nM
Beside the measured number, compound 3's estimate is 3.7-fold (0.57 log units) below it, and the stated range ends below it.
By their numbers in this assay, from the lowest: compound 2; then compounds 1 and 3 (each within the scatter of the next).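

In this assay the methyl on the aromatic carbon now stands alone as the only difference, and a 14-fold higher number from compound 2 to compound 3 (1.14 log units; beyond the scatter) is a large step for so small an addition at this position. The other difference from compound 1, hydrogen in place of methyl on a saturated chain carbon bound to an oxygen next to a carbonyl group, gives a 1.2-fold higher number from compound 1 to compound 3 (0.07 log units; within the scatter) and so leaves the number unmoved while this methyl is present. Going by these compounds, whether fluorine, chlorine or methoxy on this aromatic carbon would give a similar step stays open. What lies behind the size of the methyl step is not shown by any measurement at hand.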